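The source may hold more compounds than are shown below. What is called first, only, known or untested is meant among the compounds shown, and "the series" means these compounds.

Compound 1 `O=c1[nH]cnc2c1c(-c1ccoc1)cn2[C@@H]1O[C@H](CO)[C@@H](O)[C@H]1O` is a nucleoside that carries a furan-3-yl group on its core. In a functional assay on CCRF-CEM cells (Homo sapiens), read by MTT assay, with a stated time of 72 h (a higher number here means a weaker inhibitor, a lower number a stronger inhibitor), compound 1 gives 9030 nM, the highest of the two numbers at hand. Going by the values given here, compound 2 `CN(C)c1ncnc2c1c(-c1ccsc1)cn2[C@@H]1O[C@H](CO)[C@@H](O)[C@H]1O` differs from compound 1 in two places; in this assay compound 2 gives 3480 nM, and that gap lies beyond the scatter, but no single step connects the two. Compound 3 `O=c1[nH]cnc2c1c(-c1ccsc1)cn2[C@@H]1O[C@H](CO)[C@@H](O)[C@H]1O` is the untested partner of compound 1: thiophen-3-yl in place of furan-3-yl on an aromatic carbon. Among the compounds with values here, with no directly comparable step to rest on, the expected shift of a 1.5-fold lower number from compound 1 to compound 3 (0.18 log units; within the scatter) is modest and toward a lower number, but may not exceed the scatter. Compound 3 is estimated at 6000 nM, within 2500 nM to 15000 nM.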

Compound 3, half-maximal inhibitory concentration: 14500 nM
The estimate for compound 3 lay 2.4-fold (0.38 log units) below the measured number, within the range that was stated.
By their numbers in this assay, from the lowest: compound 2; then compounds 1 and 3 (each within the scatter of the next).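

In this assay, thiophen-3-yl in place of furan-3-yl on this aromatic carbon gives a 1.6-fold higher number from compound 1 to compound 3 (0.21 log units; within the scatter). Going by these compounds alone, this is the first direct comparison at this position, and it shows that the assay does not separate these two five-membered aromatic rings, each with one hetero atom. Going by these compounds, what stays open is whether a phenyl ring, an amine or a longer alkyl chain on the same carbon would shift the number beyond the scatter. No measurement at hand speaks to why the two rings read alike.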